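A few compounds are considered here, and "the series" means these few. Any claim that something is new, unique, unknown or untested is made for them only; others in the source may bear on it.

Measured compounds:
compound 1, `N=C(S)CCCn1nc(-c2ccccc2)ccc1=O`: 75.6%
compound 2, `CNC(=O)CCn1nc(-c2ccccc2)ccc1=O`: 3.5%
compound 3, `CCOC(=O)CCn1nc(-c2ccccc2)ccc1=O`: 6.3%

In a functional assay on the whole organism (stomach) for inhibition, with Rattus norvegicus as the target, at a dose of 100 mg/kg by the intraduodenal route (a lower number here means less inhibition, a higher number more inhibition at the dose given (going by the name of the read-out)), compound 1 gives 75.6%, while compound 3 gives 6.3%. Compound 3 thus stands far below compound 1, the gap being a number 69.3 percentage points lower from compound 1 to compound 3 (beyond the scatter), and close to compound 2, whose 3.5% lies within the usual scatter of it, as the step of a number 2.8 percentage points higher from compound 2 to compound 3 (within the scatter) shows.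

Compound 4, `O=C(O)CCn1nc(-c2ccccc2)ccc1=O`, differs from compound 3 only at the chain end: hydrogen in place of ethyl on an oxygen next to a carbonyl group. For the measured compounds named here, the one measured step that touches this same carbonyl, a number 2.8 percentage points higher from compound 2 to compound 3 (within the scatter), was small, and both variants sat far below compound 1, as a number 72.1 percentage points lower from compound 1 to compound 2 (beyond the scatter) and a number 69.3 percentage points lower from compound 1 to compound 3 (beyond the scatter) show. No change at the carbonyl end has so far moved this assay beyond the scatter, so for compound 4 no step beyond the scatter is expected, a number 1.7 percentage points higher from compound 3 to compound 4 (within the scatter) being the estimated change. Compound 4 is therefore expected to give about 8%, between 0% and 25%.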

Compound 4, a percentage reported as inhibition, in the whole organism at one dose (the size of the read-out at that dose, not a potency): 26.1%
Compound 4: the middle estimate sits 18.1 percentage points below what was measured; measured number outside the range, above it.
By their numbers in this assay, from the lowest: compounds 2 and 3 (each within the scatter of the next); then compound 4; then compound 1.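

In this assay, the carbonyl end of the chain turns out not to be silent: with hydrogen in place of ethyl on the oxygen next to the carbonyl group, turning ethoxycarbonyl into carboxy, the result is a number 19.8 percentage points higher from compound 3 to compound 4 (beyond the scatter). Hydroxy in place of methylamino on the carbonyl carbon has a similar outcome, a number 22.6 percentage points higher from compound 2 to compound 4 (beyond the scatter), so the carboxy end stands apart from both the ethoxy and methylamino variants, which lie within the scatter of each other. Even so, the sulfur-containing end group keeps a clear lead, with a number 49.5 percentage points lower from compound 1 to compound 4 (beyond the scatter).

No measurement is available to explain why the carboxy end differs from the other two. Open too, as far as these compounds go, is how much of that lead belongs to the end group and how much to the chain, which a carboxylic acid on a longer chain, or an amine at the chain end, could help to separate.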